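Working notes: benzyl in place of 4-methoxyphenoxy

A few compounds are considered here, and "the series" means these few. Any claim that something is new, unique, unknown or untested is made for them only; others in the source may bear on it.

In a functional assay (aorta) with Oryctolagus cuniculus as the target (on this read-out higher numbers stand for weaker binding and lower numbers for tighter binding), compound 1 `COc1cc(C#N)ccc1OCCCN1CCC(C(c2ccc(F)cc2)c2ccc(F)cc2)CC1` gives 2 nM, compound 2 `CC(=O)c1ccc(OCCCN2CCC(C(c3ccc(F)cc3)c3ccc(F)cc3)CC2)cc1` gives 2.51 nM and compound 3 `COc1ccc(OCCCN2CCC(C(c3ccc(F)cc3)c3ccc(F)cc3)CC2)cc1` gives 2.51 nM. Compound 3 shares its value with compound 2, and all three values lie within the scatter of one another, so compound 3 has no distinct rank in this small set.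

The next structure is compound 4 `Fc1ccc(C(c2ccc(F)cc2)C2CCN(CCCCc3ccccc3)CC2)cc1`, which carries benzyl in place of 4-methoxyphenoxy on a saturated chain carbon, three bonds along the chain from an amine nitrogen in a ring. Cut one bond further out, the same difference reads 2-(4-methoxyphenoxy)ethyl to 3-phenylpropyl.

Among the compounds with values here, three measured steps bear on this only indirectly: a 1.3-fold higher number from compound 1 to compound 2 (0.10 log units; within the scatter), a 1.3-fold higher number from compound 1 to compound 3 (0.10 log units; within the scatter) and no change at the digits printed from compound 2 to compound 3 (within the scatter). Each is small, but each only exchanges groups on the aromatic ring. Within the data shown here, all three measured compounds keep an oxygen on a saturated carbon, and compound 4 has none there, so no measured step covers this change directly.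

In this assay, no step beyond the scatter is expected, though the range is kept wide. The expected step is a 1.6-fold higher number from compound 3 to compound 4 (0.20 log units; within the scatter). The estimate for compound 4 is 4 nM, with an expected range of 1 nM to 16 nM.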

Compound 4, dissociation constant: 2.51 nM
Compound 4: middle estimate off by 1.6-fold (0.20 log units), on the high side; the range from low to high includes it.
By their numbers in this assay, from the lowest: compounds 1, 2, 3 and 4 (each within the scatter of the next).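

In this assay, benzyl in place of 4-methoxyphenoxy on a saturated chain carbon, three bonds along the chain from an amine nitrogen in a ring, gives no change at the digits printed from compound 3 to compound 4 (within the scatter), so among these compounds a value in this range does not depend on the oxygen on a saturated carbon kept by compounds 1, 2 and 3, or on the 2 hydrogen-bond acceptors counted for the group that leaves. The comparisons with the other two ethers agree, with no change at the digits printed from compound 2 to compound 4 (within the scatter) and a 1.3-fold higher number from compound 1 to compound 4 (0.10 log units; within the scatter), and they extend the earlier picture, which covered only exchanges of groups on the aromatic ring, to a change in the chain-end group itself. The data shown offer no measurement that would explain this flat response.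

From the compounds shown here alone, all four compounds have a neutral aromatic ring at the end of the chain, so it remains open whether this position would tolerate a carboxylic acid or a primary amine on that ring, or no aromatic ring at all. A longer chain is also untested by these compounds, and with every step inside the scatter, the limits of tolerance at this position cannot yet be seen.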